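Swapping the anilide ring on a shared quinazoline-free core

The source may report more compounds than this note shows. Statements on the series, on what has been measured and on what is new or still open speak of the compounds shown alone.

Of the compounds shown here, three so far share one core and differ only in the ring attached to a nitrogen on an aromatic ring. Compound 1 `COc1cc2ncnc(Nc3ccc(F)cc3)c2cc1OCCCCC(=O)Nc1ccc(S(N)(=O)=O)cc1` in a functional assay on A549 cells (Homo sapiens) for antiproliferative activity, read by MTT assay, with a stated time of 72 h (on this read-out higher numbers stand for weaker inhibition and lower numbers for stronger inhibition), reaches only a limit of the assay, > 40000 nM. Compound 2 `COc1cc2ncnc(Nc3ccc(F)c(Br)c3)c2cc1OCCCCC(=O)Nc1ccc(S(N)(=O)=O)cc1` gives 16000 nM in this assay, which is an at least 2.5-fold lower number from compound 1 to compound 2 (0.39 log units; beyond the scatter). Compound 3 `COc1cc2ncnc(Nc3cc(F)c(F)c(F)c3)c2cc1OCCCCC(=O)Nc1ccc(S(N)(=O)=O)cc1` again sits at a limit, > 40000 nM, so it stands with the weaker members and no number is known for it; the limit of > 40000 nM in this assay, at which 2 of the 3 values shown sit, describes this shared position. The step from compound 1 is a step that the two limits leave unreadable from compound 1 to compound 3, while the step of an at least 2.5-fold higher number from compound 2 to compound 3 (0.39 log units; beyond the scatter) is readable.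

Compound 4 `CCc1ccc(Nc2ncnc3cc(OC)c(OCCCCC(=O)Nc4ccc(S(N)(=O)=O)cc4)cc23)cc1` carries the change (4-ethylphenyl in place of 3,4,5-trifluorophenyl on a nitrogen on an aromatic ring). Only the two steps touching compound 3 bear on it, and they show that replacing the ring in this position can move the read-out modestly while leaving the compounds weak overall. A return toward the number of compound 2 is therefore expected at most, and compound 4 is expected to give about 30000 nM in this assay, within 8000 nM to 80000 nM, a step that is estimated as an at least 1.3-fold lower number from compound 3 to compound 4 (0.12 log units; that floor lies within the scatter).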

Compound 4, half-maximal inhibitory concentration: 12100 nM
Beside the measured number, compound 4's estimate is 2.5-fold (0.39 log units) above it; low and high end bracket the measured number.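

On the nitrogen on an aromatic ring, a ring carrying no halogen at all can bring the read-out in this assay off the limit, as seen in an at least 3.3-fold lower number from compound 3 to compound 4 (0.51 log units; beyond the scatter) and in an at least 3.3-fold lower number from compound 1 to compound 4 (0.51 log units; beyond the scatter). Until now, bromo in place of hydrogen was the only change shown to give a readable number, but the 4-ethylphenyl and 3-bromo-4-fluorophenyl rings cannot be told apart here, with a 1.3-fold lower number from compound 2 to compound 4 (0.12 log units; within the scatter), so a bromo group is not required for this level of activity. The two halogen-only rings that lack bromo, in compound 1 and compound 3, remain at a limit of the assay rather than at a number: the limit of > 40000 nM in this assay, at which 2 of the 4 values shown sit.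

From the compounds shown here alone, what the ethyl group contributes remains open, since these four compounds cannot show whether a longer chain such as propyl on the same ring would lower the number further or raise it again. It is also unknown how the read-out would respond to a ring bearing an amine or a carboxylic acid in place of the ethyl group, which would test whether this position accepts groups of a different kind.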